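The source may hold more compounds than are shown below. What is called first, only, known or untested is meant among the compounds shown, and "the series" means these compounds.

Compound 3 `COc1ccc(-c2cc(-c3ccc(Cl)cc3)n(C3C(=O)Nc4ccc(Br)cc43)n2)cc1` is the weakest of the three measured compounds in a functional assay on cells (Cancer cell lines, Homo sapiens) for cytotoxicity, read by sulforhodamine B assay, with a stated time of 48 h; on this read-out higher numbers stand for weaker inhibition of growth and lower numbers for stronger inhibition of growth: compound 3 gives 30000 nM. Compound 1 `COc1ccc(C2CC(c3ccccc3)=NN2C2=NC(=O)/C(=C3\C(=O)Nc4ccccc43)S2)cc1` gives 6040 nM in this assay, and compound 2 `COc1ccc(C2CC(c3ccccc3)=NN2C2=NC(=O)/C(=C3\C(=O)Nc4ccc(Br)cc43)S2)cc1` gives 510 nM, so both stand at lower numbers than compound 3, with compound 2 sitting furthest from it. Among the compounds with values here, the only measured single-point step is a 12-fold lower number from compound 1 to compound 2 (1.07 log units; beyond the scatter), which set bromo in place of hydrogen on an aromatic carbon and strongly lowered the number. Compound 4 `COc1ccc(-c2cc(-c3ccc(Cl)cc3)n(C3C(=O)Nc4ccc(Cl)cc43)n2)cc1` differs from compound 3 by chloro in place of bromo on an aromatic carbon. Within the data shown here, exchanging one halogen for another is not the same as placing a halogen where there was none, so that measured step bears on the present change only indirectly: it shows that the halogen at this position is felt, but no measured pair sets bromo against chloro. One therefore expects a step no larger than the scatter, no change at the digits printed from compound 3 to compound 4 (within the scatter), and estimates compound 4 at 30000 nM, within 12000 nM to 75000 nM.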

Compound 4, concentration for total growth inhibition: 23200 nM
Beside the measured number, compound 4's estimate is 1.3-fold (0.11 log units) above it; measured number inside the range.
By their numbers in this assay, from the lowest: compound 2; then compound 1; then compounds 4 and 3 (each within the scatter of the next).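

In this assay the exchange of bromo for chloro on this aromatic carbon gives a 1.3-fold lower number from compound 3 to compound 4 (0.11 log units; within the scatter) and so, on the core shared by compound 3 and compound 4, the two halogens are not told apart. The earlier step of a 12-fold lower number from compound 1 to compound 2 (1.07 log units; beyond the scatter) set bromo against hydrogen on a different core and could not show how one halogen reads against another at this place. Nothing given here explains why the two halogens read alike.

The compounds shown leave open whether hydrogen in this place on the core of compound 3 would read differently from either halogen, and whether chloro would match bromo on the core of compound 2. They also leave open how an amine or a carboxylic acid on this aromatic carbon would read on either core.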